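The source may hold more compounds than are shown below. What is called first, only, known or untested is meant among the compounds shown, and "the series" means these compounds.

Compound 1 `Cc1cnn(C(=O)N(C)CCN(C)Cc2ccc(OCc3ccccc3)cc2)c1` and compound 2 `CN(CCN(C)C(=O)n1cccn1)Cc1ccc(OCc2ccccc2)cc1` share a core and differ in one place. In an assay on membranes from brain for binding affinity to Monoacylglycerol lipase ABHD6 (Mus musculus), read by fluorescence, with stated times of 1 h and 30 min (on this read-out higher numbers stand for weaker inhibition and lower numbers for stronger inhibition), compound 1 gives 1200 nM, and in this assay compound 2 gives 530 nM. The change between them, (hydrogen in place of methyl on an aromatic carbon), therefore yields a 2.3-fold lower number from compound 1 to compound 2 (0.35 log units; beyond the scatter).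

Compound 3 `Cc1cnn(C(=O)N2CCN(C(c3ccc4ccccc4c3)c3ccc4ccccc4c3)CC2)c1` carries a different core; how that core differs from the core of compound 1 is not broken down here. In this assay compound 3 gives only a limit, > 100000 nM, and no number. That is the limit of > 100000 nM in this assay, at which 1 of the 3 values shown sits, so nothing is known about where its true value lies beyond that boundary.

Compound 4 `O=C(N1CCN(C(c2ccc3ccccc3c2)c2ccc3ccccc3c2)CC1)n1cccn1` has not yet been measured. It arises from compound 3 by the same change that turned compound 1 into compound 2, namely (hydrogen in place of methyl on an aromatic carbon). By analogy with the earlier step, compound 4 is expected to show a number no higher from compound 3 to compound 4 (the limit leaves the size open), resting on the modest gain seen as a 2.3-fold lower number from compound 1 to compound 2 (0.35 log units; beyond the scatter). Since that gain is small against the limit of compound 3, compound 4 is estimated at 100000 nM, ranging from 30000 nM to 300000 nM, and most likely to be reported only as a limit again.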

Compound 4, half-maximal inhibitory concentration: > 100000 nM
Compound 4: a limit, no number (the forecaster's own chance of this, stated with the estimate: 70%); the middle value lies on the limit itself.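

Compound 4, like compound 3, is reported only as a limit in this assay, so no step can be read between the two: the limit of > 100000 nM in this assay, at which 2 of the 4 values shown sit.

The compounds shown leave open where the true values of compound 3 and compound 4 lie, and whether going from 4-methyl-1H-pyrazol-1-yl to 1H-pyrazol-1-yl changes anything on this core.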